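Ester swap on a weak methyl-substituted compound

A few compounds are considered here, and "the series" means these few. Any claim that something is new, unique, unknown or untested is made for them only; others in the source may bear on it.

compound 1 `CCOC(=O)c1sc2ccccc2c1Nc1cc(OC)c(OC)c(OC)c1`: 3100 nM
compound 2 `CCOC(=O)c1sc2cccc(C)c2c1Nc1cc(OC)c(OC)c(OC)c1`: 2520 nM
compound 3 `CCOC(=O)c1sc2cc(C)ccc2c1Nc1cc(OC)c(OC)c(OC)c1`: 0.38 nM

In a functional assay on HeLa cells (Homo sapiens) for cytotoxicity, read by MTT assay, with a stated time of 72 h (on this read-out lower numbers stand for stronger inhibition and higher numbers for weaker inhibition), compound 2 gives 2520 nM, which lies within the scatter of compound 1 and far above compound 3 at 0.38 nM. Compound 4 `COC(=O)c1sc2cccc(C)c2c1Nc1cc(OC)c(OC)c(OC)c1` differs from compound 2 by hydrogen in place of methyl on a saturated chain carbon bound to an oxygen next to a carbonyl group, ethoxycarbonyl to methoxycarbonyl. Within the data shown here, no measured step touches this ester. The two steps available are both methyl in place of hydrogen on an aromatic carbon, at other places: a 1.2-fold lower number from compound 1 to compound 2 (0.09 log units; within the scatter), and an 8200-fold lower number from compound 1 to compound 3 (3.91 log units; beyond the scatter). The second warns that a small change can matter, so the range is kept wide. No change beyond the scatter is expected in this assay, and neither direction is favoured. The expected step is a 1.1-fold lower number from compound 2 to compound 4 (0.06 log units; within the scatter). Compound 4 is estimated at 2200 nM, within an expected range of 600 nM to 8000 nM.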

Compound 4, half-maximal inhibitory concentration: 1300 nM
For compound 4 the middle estimate is 1.7-fold (0.23 log units) above the measured one; measured number inside the range.
By their numbers in this assay, from the lowest: compound 3; then compounds 4, 2 and 1 (each within the scatter of the next, the first and the last beyond it).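

In this assay, the change from ethoxycarbonyl to methoxycarbonyl gives a 1.9-fold lower number from compound 2 to compound 4 (0.29 log units; within the scatter). Among these compounds, this is the first measured step at the ester, and it shows that, with this methyl-substituted core, ethyl can give way to methyl without a change beyond the scatter. Nothing available here offers an explanation for this result. The compounds shown leave open whether the same swap would hold up on compound 3 at 0.38 nM. They also leave open what a longer chain, a carboxylic acid or an amide would do in place of this ester.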